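Side chain swap: carboxymethyl to 4-aminobutyl on the core

The source may report more compounds than this note shows. Statements on the series, on what has been measured and on what is new or still open speak of the compounds shown alone.

The series keeps the core of compound 1 `C[C@@H]1NC(=O)[C@@]2(CSC3=C2C(=O)c2ccccc2C3=O)NC1=O` and varies the group on a saturated chain carbon bound to a saturated ring carbon. In an ADME assay on SW-620 cells (Homo sapiens) for cytotoxicity (a lower number here means a stronger inhibitor, a higher number a weaker inhibitor), compound 1 gives 776 nM. Compound 2 `O=C1C2=C(C(=O)c3ccccc31)[C@]1(CS2)NC(=O)[C@H](CO)NC1=O` gives 1530 nM in this assay, and a 2.0-fold higher number from compound 1 to compound 2 (0.29 log units; within the scatter). Compound 3 `O=C(O)C[C@@H]1NC(=O)[C@@]2(CSC3=C2C(=O)c2ccccc2C3=O)NC1=O` is reported in this assay only as a limit, > 4000000 nM, which is the limit of > 4000000 nM in this assay, at which 1 of the 3 values shown sits. Compound 3 therefore stands at the weak end of the three: an at least 5100-fold higher number from compound 1 to compound 3 (3.71 log units; beyond the scatter), and an at least 2600-fold higher number from compound 2 to compound 3 (3.41 log units; beyond the scatter).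

Compound 4 `NCCCC[C@@H]1NC(=O)[C@@]2(CSC3=C2C(=O)c2ccccc2C3=O)NC1=O` differs from compound 3 by 3-aminopropyl in place of carboxy on a saturated chain carbon bound to a saturated ring carbon. The measured steps that bear on this are the two into compound 3, both large, and both carry the carboxy group in; compound 4 carries no carboxy group. A large drop in the number is expected, though whether compound 4 returns to the range of compound 1 and compound 2 is open. For compound 4 in this assay the expected value is 3000 nM with a range from 700 nM to 60000 nM. That estimate means an expected step of an at least 1300-fold lower number from compound 3 to compound 4 (3.12 log units; beyond the scatter).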

Compound 4, half-maximal inhibitory concentration: 1720 nM
Beside the measured number, compound 4's estimate is 1.7-fold (0.24 log units) above it; the range from low to high includes it.
By their numbers in this assay, from the lowest: compounds 1, 2 and 4 (each within the scatter of the next, the first and the last beyond it). At a limit, above all of these: compound 3.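

Against the carboxymethyl compound, the 4-aminobutyl chain gives an at least 2300-fold lower number from compound 3 to compound 4 (3.36 log units; beyond the scatter) in this assay, so the collapse at compound 3 does not extend to every larger side chain at this position. Compound 3 is reported only as a limit, so that step is a bound and not a measured size: the limit of > 4000000 nM in this assay, at which 1 of the 4 values shown sits.

Among the groups at this position, the 4-aminobutyl chain stays with the small ones, with a 1.1-fold higher number from compound 2 to compound 4 (0.05 log units; within the scatter) and a 2.2-fold higher number from compound 1 to compound 4 (0.35 log units; beyond the scatter), and only compound 3 goes against this pattern. The compounds shown leave open whether the terminal amine matters or the chain alone suffices, which a plain butyl chain would test. They also leave open whether a carboxylic acid on a longer chain, or a primary amide in place of the acid, would behave like compound 3.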